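A few compounds are considered here, and "the series" means these few. Any claim that something is new, unique, unknown or untested is made for them only; others in the source may bear on it.

Measured in a physicochemical assay for solubility, in phosphate buffer, measured as kinetic solubility, at pH 7.4; a higher number here means a more soluble compound, a lower number a less soluble compound:
- compound 1 `Cc1oc(-c2c(Cl)cccc2Cl)nc1CN1CCC(C(=O)NCCCN2C[C@H](C)C[C@H](C)C2)CC1`: > 77 ug/mL
- compound 2 `Cc1cccc(Cl)c1-c1nc(CN2CCC(C(=O)NCCCN3CCCC(C)C3)CC2)c(C)o1`: 52.6 ug/mL

Compound 1 reads > 77 ug/mL, which is a limit of the assay and not a number. Its true solubility is therefore not pinned down. Among the compounds with values here, compound 2 gives 52.6 ug/mL, the only exact number so far. Within the data shown here, no two measured compounds differ in one place only, so no measured step is available as a guide.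

Compound 3 `Cc1oc(-c2c(Cl)cccc2C(F)(F)F)nc1CN1CCC(C(=O)NCCCN2C[C@H](C)C[C@H](C)C2)CC1` keeps the core of compound 1 and carries one change, trifluoromethyl in place of chloro on an aromatic carbon, so that 2,6-dichlorophenyl becomes 2-chloro-6-(trifluoromethyl)phenyl. A modest fall in this assay is expected, and the estimated move is an at least 1.4-fold lower number from compound 1 to compound 3 (0.14 log units; that floor lies within the scatter), although a result within the usual scatter of the limit would be no surprise. The estimate for compound 3 is 55 ug/mL, with an expected range of 25 ug/mL to 90 ug/mL.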

Compound 3, solubility: 65.1 ug/mL
Compound 3: the middle estimate sits 1.2-fold (0.07 log units) below what was measured; the range from low to high includes it.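

Trifluoromethyl in place of chloro on this aromatic carbon gives the first step between two measured compounds in this assay: an at least 1.1-fold lower number from compound 1 to compound 3 (0.07 log units; that floor lies within the scatter). Compound 1 reads > 77 ug/mL, which is a limit and not a number. The step is therefore only a floor, and its true size may be larger, because the reading for compound 1 is capped: the limit of > 77 ug/mL in this assay, at which 1 of the 3 values shown sits.

From the compounds shown here alone, how a different kind of group on this carbon, such as a nitrile, a methoxy group or an amine, would read in this assay remains open. Compound 2 differs from compound 1 in more than one place, so it gives no separate reading of this position, and the effect of the change on other parts of the shared core is also unknown.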